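Swapping the nitro ring for a bromophenyl: an expectation

This account rests on a few compounds, and the source may have more. Where it says the series, first, only, none or still open, it means among the compounds named here.

Measured in a functional assay on OVCAR cells (Homo sapiens) for cytotoxicity, read by sulforhodamine B assay, with a stated time of 48 h; on this read-out higher numbers stand for weaker inhibition and lower numbers for stronger inhibition:
Compound 1, `CC(=O)N1N=C(c2cccc3ccccc23)CC1c1ccccc1[N+](=O)[O-]`, gives 4320 nM.
Compound 2, `O=CCN1N=C(c2ccc3ccccc3c2)CC1c1ccccc1[N+](=O)[O-]`, gives 3480 nM.

In this assay compound 2 and compound 1 sit within the scatter of each other, so neither can be called the stronger. Compound 3, `O=CCN1N=C(c2ccc3ccccc3c2)CC1c1cccc(Br)c1`, is not yet measured. It differs from compound 2 by 3-bromophenyl in place of 2-nitrophenyl on a saturated ring carbon. Going by the values given here, no measured pair shows the effect of such a change, so compound 3 is expected to stay close to compound 2, with a step of a 1.1-fold higher number from compound 2 to compound 3 (0.06 log units; within the scatter) that is not beyond the scatter. Compound 3 is therefore estimated at 4000 nM, within 1500 nM to 11000 nM.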

Compound 3, half-maximal inhibitory concentration: 10800 nM
Compound 3: middle estimate off by 2.7-fold (0.43 log units), on the low side, and the stated range covers the measured number.
By their numbers in this assay, from the lowest: compounds 2 and 1 (each within the scatter of the next); then compound 3.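

In this assay, the saturated ring carbon next to the ring nitrogen proves sensitive to its aryl group: 3-bromophenyl in place of 2-nitrophenyl brings a 3.1-fold higher number from compound 2 to compound 3 (0.49 log units; beyond the scatter), the only step shown here. That swap alters both the substituent and its place on the phenyl ring, so the two changes cannot be separated. Nothing available explains the step. As far as these compounds go, it remains open whether the weaker inhibition follows the arrival of bromine or the departure of the nitro group. From the compounds shown here alone, how an amine or a carboxylic acid on this phenyl ring would read also remains open.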